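Amide-aryl variation on the shared core, step to compound 4

This account rests on a few compounds, and the source may have more. Where it says the series, first, only, none or still open, it means among the compounds named here.

Three analogues of the shared core differ only in the group on the amide carbonyl. Compound 1 `CN1[C@@H]2c3[nH]c4ccccc4c3C[C@H]1[C@H](C#N)N1[C@@H](CNC(=O)c3cccc4c3CCCC4)c3[nH]c4ccccc4c3C[C@@H]21` carries 1,2,3,4-tetrahydronaphthalen-5-yl and in a functional assay on HCT-116 cells (Homo sapiens) for cytotoxicity, read by MTT assay, with a stated time of 72 h (on this read-out higher numbers stand for weaker inhibition and lower numbers for stronger inhibition), compound 1 gives 4210 nM. Compound 2 `CN1[C@@H]2c3[nH]c4ccccc4c3C[C@H]1[C@H](C#N)N1[C@@H](CNC(=O)c3ccc4ccccc4n3)c3[nH]c4ccccc4c3C[C@@H]21` carries quinolin-2-yl and in this assay compound 2 gives 240 nM. Compound 3 `CN1[C@@H]2c3[nH]c4ccccc4c3C[C@H]1[C@H](C#N)N1[C@@H](CNC(=O)c3cc4ccccc4[nH]3)c3[nH]c4ccccc4c3C[C@@H]21` carries 1H-indol-2-yl and in this assay compound 3 gives 880 nM, the second highest number of the three: the step of a 3.7-fold higher number from compound 2 to compound 3 (0.56 log units; beyond the scatter) and the step of a 4.8-fold lower number from compound 1 to compound 3 (0.68 log units; beyond the scatter) place it between the other two, both gaps beyond the scatter.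

Compound 4 `CN1[C@@H]2c3[nH]c4ccccc4c3C[C@H]1[C@H](C#N)N1[C@@H](CNC(=O)/C=C/c3cccc(C(F)(F)F)c3)c3[nH]c4ccccc4c3C[C@@H]21` introduces the change (2-(3-(trifluoromethyl)phenyl)ethenyl in place of 1H-indol-2-yl on a carbonyl carbon). Going by the values given here, no measured pair involves a group of this kind, so no step bears on it directly. What the measured steps show is that changing the amide aryl moves this assay considerably: an 18-fold lower number from compound 1 to compound 2 (1.24 log units; beyond the scatter), a 4.8-fold lower number from compound 1 to compound 3 (0.68 log units; beyond the scatter), a 3.7-fold higher number from compound 2 to compound 3 (0.56 log units; beyond the scatter). The entering group shares with the group of compound 1 the absence of hydrogen-bond donors and acceptors, and compound 1 gives the highest number of the set. On that thin basis the number for compound 4 is expected to rise, step a 2.3-fold higher number from compound 3 to compound 4 (0.36 log units; beyond the scatter), with wide uncertainty. Compound 4 is thus estimated at 2000 nM, in the range 500 nM to 8000 nM.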

Compound 4, half-maximal inhibitory concentration: 610 nM
Beside the measured number, compound 4's estimate is 3.3-fold (0.52 log units) above it; measured number inside the range.
By their numbers in this assay, from the lowest: compound 2; then compounds 4 and 3 (each within the scatter of the next); then compound 1.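

The group on the carbonyl carbon need not be a ring attached directly: 2-(3-(trifluoromethyl)phenyl)ethenyl, with its double bond outside aromatic rings, cannot be told apart from 1H-indol-2-yl in this assay, the step being a 1.4-fold lower number from compound 3 to compound 4 (0.16 log units; within the scatter) and so no real difference. A group with no hydrogen-bond donor can therefore read level with one that has a donor, and the absence of donors and acceptors does not by itself go with the highest number: compound 1 shares that absence, yet the comparison gives a 6.9-fold lower number from compound 1 to compound 4 (0.84 log units; beyond the scatter) in favour of the new group. Quinolin-2-yl keeps the lowest number of the set, with a 2.5-fold higher number from compound 2 to compound 4 (0.41 log units; beyond the scatter) marking a gap beyond the scatter.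

Nothing available here accounts for these differences. Still open, going by these compounds, is which part of the entering group carries its level: the ethenyl link could be tested against the saturated 2-(3-(trifluoromethyl)phenyl)ethyl group, and the trifluoromethyl against a carboxylic acid or an amine on the phenyl ring.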